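Trading a methoxy for a hydroxy on a weakly toxic scaffold

A few compounds are considered here, and "the series" means these few. Any claim that something is new, unique, unknown or untested is made for them only; others in the source may bear on it.

The three measured compounds share one core and differ at two arms. Compound 1 `COc1cc(C)cc(-c2c(-c3ccnc(-c4ccc(C(C)=O)cc4)c3)cnn2CC#N)c1` carries a methoxy and an acetyl-bearing ring; in a functional assay on BT-549 cells (Homo sapiens) for inhibition, read by sulforhodamine B assay, with a stated time of 48 h (on this read-out lower numbers stand for higher toxicity in this test and higher numbers for lower toxicity in this test), compound 1 reaches only the limit of the test, > 100000 nM. Compound 2 `Cc1cc(O)cc(-c2nn(CC#N)cc2-c2ccnc(-c3ccc(Oc4ccccc4)cc3)c2)c1` carries a hydroxy and a phenoxy-bearing ring; in this assay compound 2 gives 43100 nM. Compound 3 `COc1cc(C)cc(-c2nn(CC#N)cc2-c2ccnc(-c3ccc(N(C)C)cc3)c2)c1` pairs the methoxy with a dimethylamino-bearing ring. In this assay compound 3 again reaches only the limit, > 100000 nM. Two of the three values thus sit at the same edge of the test (the limit of > 100000 nM in this assay, at which 2 of the 3 values shown sit), so compound 3 stands among those with no measurable toxicity here.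

Compound 4 `Cc1cc(O)cc(-c2nn(CC#N)cc2-c2ccnc(-c3ccc(N(C)C)cc3)c2)c1` keeps the dimethylamino arm of compound 3 and makes one change: hydrogen in place of methyl on an oxygen on an aromatic ring. Going by the values given here, no measured pair shows this change alone. Among the compounds with values here, compound 2, the only hydroxy compound, gives a number where the two methoxy compounds give limits, but it differs in a second arm as well. A modest move toward higher toxicity is therefore expected, an at least 1.2-fold lower number from compound 3 to compound 4 (0.09 log units; that floor lies within the scatter), with a real chance that only a limit is reported again. Compound 4 is estimated at 80000 nM, within 30000 nM to 200000 nM.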

Compound 4, concentration lethal to 50% of the cells: > 100000 nM
Compound 4: a limit, no number; the forecaster's own chance of this, stated with the estimate: 55%; middle value at least 1.2-fold (0.09 log units) from the limit.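

In this assay compound 4 gives > 100000 nM, which is a limit and not a number, and compound 3 also stands at a limit, so the step between them cannot be read. Going by these compounds alone, with the hydroxy held constant, dimethylamino in place of phenoxy on an aromatic carbon gives an at least 2.3-fold higher number from compound 2 to compound 4 (0.36 log units; beyond the scatter), which shows that the hydroxy alone does not bring a measurable value and that, of these two compounds, only the one with the phenoxy arm gives a number. Most of the set now sits at one edge of the test: the limit of > 100000 nM in this assay, at which 3 of the 4 values shown sit.

As far as these compounds go, whether swapping methoxy for hydroxy changes toxicity at all stays open, and a methoxy compound with the phenoxy arm would address this. From the compounds shown here alone, it is also open whether a carboxylic acid or a primary amine in place of dimethylamino would give a number in this assay.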